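The source may report more compounds than this note shows. Statements on the series, on what has been measured and on what is new or still open speak of the compounds shown alone.

Three compounds in the series have numbers in an assay for inhibition of protein disulfide-isomerase (Homo sapiens), with a stated time of 1 h; on this read-out higher numbers stand for weaker inhibition and lower numbers for stronger inhibition. Compound 1 `Oc1c(C(Nc2ccccn2)c2ccccc2Cl)ccc2cccnc12` gives 500 nM. Compound 2 `Oc1ccc2[nH]ncc2c1C(c1ccc(-n2cccc2)cc1)N1CCCCC1` gives 290 nM. Compound 3 `COc1ccc(C(Nc2cc(C)ccn2)c2ccc3cccnc3c2O)cc1O` gives 150 nM, the lowest of the three numbers; its gap to compound 2 lies within the scatter, so no order between these two can be read, while its gap to compound 1 lies beyond the scatter.

Compound 4 `Cc1ccnc(NC(c2cccc(F)c2)c2ccc3cccnc3c2O)c1` has not been measured. It differs from compound 3 in one place: 3-fluorophenyl in place of 3-hydroxy-4-methoxyphenyl on a saturated chain carbon bound to an aromatic carbon and a nitrogen on an aromatic ring. Going by the values given here, no step between measured compounds isolates this change, so the expectation rests on the whole set. The direction expected for compound 4 is toward a somewhat higher number than compound 3, since compound 1 gives 500 nM while also carrying an aryl group without hydroxyl or methoxy on that saturated carbon, though compound 1 differs in the amine as well. The size of the step is uncertain and may not exceed the scatter. The step from compound 3 to compound 4 is estimated at a 2.3-fold higher number from compound 3 to compound 4 (0.37 log units; beyond the scatter). Compound 4 is expected to give 350 nM, with a range of 120 nM to 1000 nM.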

Compound 4, half-maximal inhibitory concentration: 350 nM
The estimate for compound 4 equals the measured number at the digits printed; the measured number falls inside the stated range.
By their numbers in this assay, from the lowest: compounds 3, 2, 4 and 1 (each within the scatter of the next, the first and the last beyond it).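

In this assay, going by these compounds alone, a 2.3-fold higher number from compound 3 to compound 4 (0.37 log units; beyond the scatter) is the first change made in one place only, and it shows that the aryl group on the saturated chain carbon bound to an aromatic carbon and a nitrogen on an aromatic ring affects the number when the rest of the structure is held fixed. The step is modest: with 3-fluorophenyl at this place, the hydrogen-bond donor and acceptors of 3-hydroxy-4-methoxyphenyl are gone, yet compound 4 still gives 350 nM, so inhibition at this place does not depend entirely on those groups. No measurement on hand explains the step or ties it to any single feature of the change.

The change removes the hydroxy and methoxy groups and adds fluorine in a single move, so the compounds shown cannot assign the step to any one of these, and unsubstituted phenyl, 3-hydroxyphenyl and 4-methoxyphenyl at this place would be the direct tests. Also open, as far as these compounds go, is whether an aminomethyl or carboxylic acid group on this aryl ring would be accepted, and whether the step would carry over to a different amine on the same saturated carbon.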